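Amide variation on the thiophene-carboxamide series: compound 4

A few compounds are considered here, and "the series" means these few. Any claim that something is new, unique, unknown or untested is made for them only; others in the source may bear on it.

Measured so far:
compound 1 `CCN(CC)C(=O)c1ccc(-c2cc(-c3cc(OC)ccc3OC)no2)s1` — 11000 nM
compound 2 `CCN(CC)C(=O)c1ccc(-c2cc(C3=CC(=O)C=CC3=O)no2)s1` — 10000 nM
compound 3 `O=C1C=CC(=O)C(c2cc(-c3ccc(C(=O)N4CCCC4)s3)on2)=C1` — a limit, > 30000 nM

In a functional assay on A549 cells (Homo sapiens) for cytotoxicity, read by XTT assay, with a stated time of 72 h (a lower number here means a stronger inhibitor, a higher number a weaker inhibitor), compound 1 gives 11000 nM and compound 2 gives 10000 nM; these two numbers sit within the scatter of each other, so no order between them is claimed. For compound 3 this assay reports only a limit, > 30000 nM. Among the two numbers shown, compound 1 has the higher one, with compound 2 nearest.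

Going by the values given here, the single measured step that changes the amide, an at least 3.0-fold higher number from compound 2 to compound 3 (0.47 log units; beyond the scatter), replaces diethylamino with a cyclic amine and weakens the compound at least modestly, ending at the limit of > 30000 nM in this assay, at which 1 of the 3 values shown sits.

Compound 4 `COc1ccc(OC)c(-c2cc(-c3ccc(C(=O)N4CCC(C(F)(F)F)CC4)s3)on2)c1` makes a related change on compound 1: 4-(trifluoromethyl)piperidin-1-yl in place of diethylamino on a carbonyl carbon. Among the compounds with values here, the only guide is the step from compound 2 to compound 3, which went the same way, from an open diethylamino to a ring amine, and gave a weaker inhibitor. A weakening of similar or larger size is therefore expected for compound 4, and the value may again end as a limit of this assay.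

Compound 4 is estimated at 28000 nM, with a range from 9000 nM to 90000 nM. This estimate means a step of a 2.5-fold higher number from compound 1 to compound 4 (0.41 log units; beyond the scatter), in the direction of a weaker inhibitor.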

Compound 4, half-maximal inhibitory concentration: > 30000 nM
Compound 4 gave a limit, no number (the forecaster's own chance of this, stated with the estimate: 45%); at least 1.0-fold (0.02 log units) between middle value and limit.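

Replacing diethylamino on a carbonyl carbon with 4-(trifluoromethyl)piperidin-1-yl gives an at least 2.7-fold higher number from compound 1 to compound 4 (0.43 log units; beyond the scatter) in this assay, so a weaker inhibitor now also follows a ring amine on the core of compound 1. The earlier at least 3.0-fold higher number from compound 2 to compound 3 (0.47 log units; beyond the scatter) rested on a single pair, whereas the same direction now holds in two pairs that carry different groups on the unchanged part of the molecule, and no compound shown goes against it. Compound 4 reports only a limit, and the series now meets this ceiling twice among its ring amides: the limit of > 30000 nM in this assay, at which 2 of the 4 values shown sit.

Going by these compounds, both steps end at a limit, so their true sizes remain unknown and they cannot be ranked against each other, nor can the ring be separated from the trifluoromethyl group in compound 4. An unsubstituted piperidine would separate those two contributions, while a dimethylamino amide or an open chain longer than ethyl would show whether any change from diethylamino at this place keeps a measurable number.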